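Swapping benzylamino for 3-nitrophenyl on a carbonyl carbon

This account rests on a few compounds, and the source may have more. Where it says the series, first, only, none or still open, it means among the compounds named here.

Compound 1 `CC1=CC[C@H]2[C@@H]1CC=C(C)[C@@H](CCC1=C(C)CC[C@@H]3OC(C)(C)[C@@H](O)CC[C@@]13C)C2(C)C` reports > 50000 nM in a functional assay on MCF7 cells (Homo sapiens) for antiproliferative activity, read by MTT assay, with a stated time of 72 h (a lower number here means a stronger inhibitor, a higher number a weaker inhibitor), and this value is a limit. Within the data shown here, compound 2 `CC1=CC[C@H]2[C@H](CC[C@]2(C)O)C(C)(C)[C@@H]1CC[C@H]1[C@]2(C)CC[C@H](OC(=O)NCc3ccccc3)C(C)(C)O[C@H]2CC[C@@]1(C)O` gives 24500 nM in this assay as the only actual number so far. Compound 3 `CC1=CC[C@H]2[C@H](CC[C@]2(C)O)C(C)(C)[C@@H]1CC[C@H]1[C@]2(C)CC[C@H](OC(=O)c3cccc([N+](=O)[O-])c3)C(C)(C)O[C@H]2CC[C@@]1(C)O` carries 3-nitrophenyl in place of benzylamino on a carbonyl carbon. Among the measured compounds shown here, no measured step yet shows what such a swap does, so no change beyond the usual scatter is expected in this assay in either direction. The expected move is a 1.1-fold higher number from compound 2 to compound 3 (0.06 log units; within the scatter) and it is only an estimate. For compound 3 the estimated value is 28000 nM (expected range 11000 nM to 50000 nM).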

Compound 3, half-maximal inhibitory concentration: 36000 nM
Beside the measured number, compound 3's estimate is 1.3-fold (0.11 log units) below it; measured number inside the range.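

Among these compounds, the first measured step at this place, a carbonyl carbon whose other neighbour is oxygen next to a carbonyl group, is a 1.5-fold higher number from compound 2 to compound 3 (0.17 log units; within the scatter) in this assay. Benzylamino and 3-nitrophenyl therefore read alike here, and this swap does not give a clearly stronger inhibitor. Compound 1 stands at the upper end of the assay, a limit and not a number: the limit of > 50000 nM in this assay, at which 1 of the 3 values shown sits.

Still open, on these data alone, is whether any group on this carbonyl carbon can give a clearly lower number. A simple amine, a carboxylic acid or a longer chain there would test this.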